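Moving the methoxy group: from compound 2 to compound 3

A few compounds are considered here, and "the series" means these few. Any claim that something is new, unique, unknown or untested is made for them only; others in the source may bear on it.

Measured so far in a functional assay on GTL 16 cells for antiproliferative activity against GTL 16 cell line (Homo sapiens), read by CCK-8 assay, with a stated time of 72 h; a higher number here means a weaker inhibitor, a lower number a stronger inhibitor:
compound 1 `Cc1ccc(C(=O)Nc2cccc(-c3oc4cc(-c5ccc(F)cc5)ccc4c(=O)c3O)c2)cc1` gives 12900 nM
compound 2 `COc1ccccc1C(=O)Nc1cccc(-c2oc3cc(-c4ccc(F)cc4)ccc3c(=O)c2O)c1` gives 6370 nM

Of the two numbers measured, compound 2 carries the lower one; the gap to the other is the step of a 2.0-fold lower number from compound 1 to compound 2 (0.31 log units; beyond the scatter), which replaced a 4-methylphenyl with a 2-methoxyphenyl on the carbonyl carbon and came out as a modest improvement, beyond the usual scatter. Compound 3 `COc1cccc(C(=O)Nc2cccc(-c3oc4cc(-c5ccc(F)cc5)ccc4c(=O)c3O)c2)c1` keeps everything in compound 2 except one point: 3-methoxyphenyl in place of 2-methoxyphenyl on a carbonyl carbon. The two compounds are built from the same atoms joined differently, so the difference lies only in where the methoxy group sits on that ring. Going by the values given here, no measured step shifts a methoxy group from one place to another; the single step available, from compound 1 to compound 2, exchanged one whole ring substituent for another and does not tell how such a shift will read. Without a guide, the expected change a 1.1-fold higher number from compound 2 to compound 3 (0.04 log units; within the scatter) is taken as none beyond the scatter, in either direction. Compound 3 is therefore estimated at 7000 nM in this assay, with a range from 2500 nM to 20000 nM.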

Compound 3, half-maximal inhibitory concentration: 12500 nM
For compound 3 the middle estimate is 1.8-fold (0.25 log units) below the measured one, within the range that was stated.
By their numbers in this assay, from the lowest: compounds 2, 3 and 1 (each within the scatter of the next, the first and the last beyond it).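

In this assay, going by these compounds alone, the shift from 2-methoxyphenyl to 3-methoxyphenyl on the carbonyl carbon gives the first direct look at where a methoxy group sits on this ring, and it reads a 2.0-fold higher number from compound 2 to compound 3 (0.29 log units; within the scatter), so this assay cannot separate the two placements. The exchange of 4-methylphenyl for 3-methoxyphenyl reads a 1.0-fold lower number from compound 1 to compound 3 (0.01 log units; within the scatter), which means that compound 3 also cannot be separated from compound 1, and only a 2.0-fold lower number from compound 1 to compound 2 (0.31 log units; beyond the scatter) remains beyond the scatter, so a methoxy group on this ring does not by itself guarantee a step of that kind. Nothing measured here speaks to why these numbers fall as they do.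

Going by these compounds, how this ring would read with an amine or a carboxylic acid in place of the methoxy group remains open, as does the effect of a longer chain such as ethoxy. Within the data shown here, these three compounds also leave open whether the one step beyond the scatter would hold up on a core other than the one they share.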